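The compounds below may be only part of what the source reports. "The series", "measured", "known", "first", "only" and "open" are said of these compounds alone.

Compound 1 `C/C(=C\CC/C(C)=C/CC[C@@H]1[C@@]2(C)CCC(=O)C(C)(C)[C@H]2CC[C@@]1(C)O)CC/C=C(\C)C(=O)OCc1cn(-c2ccc(C(F)(F)F)cc2)nn1` and compound 2 `COc1ccc(-n2cc(COC(=O)/C(C)=C/CC/C(C)=C/CC/C(C)=C/CC[C@@H]3[C@@]4(C)CCC(=O)C(C)(C)[C@H]4CC[C@@]3(C)O)nn2)cc1` share their core with compound 3 `C/C(=C\CC/C(C)=C/CC[C@@H]1[C@@]2(C)CCC(=O)C(C)(C)[C@H]2CC[C@@]1(C)O)CC/C=C(\C)C(=O)OCc1cn(-c2cccc(Cl)c2)nn1` and differ from it only in the group on the aromatic nitrogen. In a functional assay on A549 cells (Homo sapiens) for antiproliferative activity, read by MTT assay, with a stated time of 48 h (on this read-out higher numbers stand for weaker inhibition and lower numbers for stronger inhibition), compound 1 gives only a limit of the assay, > 150000 nM. In this assay compound 2 likewise gives only a limit, > 150000 nM. Among the measured compounds shown here, compound 3 is the one compound of the three that returns a number in this assay, namely 147000 nM, and that number sits just under (the limit of > 150000 nM in this assay, at which 2 of the 3 values shown sit). The steps of an at least 1.0-fold lower number from compound 1 to compound 3 (0.00 log units; that floor lies within the scatter) and an at least 1.0-fold lower number from compound 2 to compound 3 (0.00 log units; that floor lies within the scatter) are floors that the limits leave unreadable, and the step that the two limits leave unreadable from compound 1 to compound 2 cannot be read at all. Compound 4 `C/C(=C\CC/C(C)=C/CC[C@@H]1[C@@]2(C)CCC(=O)C(C)(C)[C@H]2CC[C@@]1(C)O)CC/C=C(\C)C(=O)OCc1cn(-c2cccc(O)c2)nn1` differs from compound 3 by hydroxy in place of chloro on an aromatic carbon. The two steps that change the aryl group bear on this change, but both are floors that tell nothing beyond the scatter, so the expected step is a 1.0-fold higher number from compound 3 to compound 4 (0.01 log units; within the scatter). Compound 4 is therefore estimated at 150000 nM, between 60000 nM and 350000 nM, with a real chance that this assay again reports only a limit for it.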

Compound 4, half-maximal inhibitory concentration: 42800 nM
Compound 4: the middle estimate sits 3.5-fold (0.54 log units) above what was measured; the whole stated range lies above it.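

In this assay, among the compounds shown here, hydroxy in place of chloro on an aromatic carbon, meta to a large group, gives a 3.4-fold lower number from compound 3 to compound 4 (0.54 log units; beyond the scatter), the only step here between two actual numbers, so the group at this place does change the read-out. The 3-hydroxyphenyl compound also stands apart from the other two aryl compounds, with an at least 3.5-fold lower number from compound 2 to compound 4 (0.54 log units; beyond the scatter) and an at least 3.5-fold lower number from compound 1 to compound 4 (0.54 log units; beyond the scatter), both of them floors. The earlier aryl steps stayed within the scatter or unreadable because of the assay's limit: the limit of > 150000 nM in this assay, at which 2 of the 4 values shown sit.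

The compounds shown leave open whether this drop belongs to hydroxy alone or would also come with an amine or a carboxylic acid at the same place. Also open, on these data alone, is whether hydroxy at the place that carries methoxy in compound 2 would give a similar step.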